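A Hydroxy Group Enters the Core of Compound 1

A few compounds are considered here, and "the series" means these few. Any claim that something is new, unique, unknown or untested is made for them only; others in the source may bear on it.

Compound 1, `COc1ccccc1-c1cc(=O)c2cc(NC(C)=O)ccc2o1`, is the point of departure. In an ADME assay on THP-1 cells (Homo sapiens) for cytotoxicity, read by flow cytometry and propidium iodide staining, with a stated time of 72 h (on this read-out higher numbers stand for weaker inhibition and lower numbers for stronger inhibition), compound 1 gives 50000 nM, the lowest of the two numbers recorded in this set. Compound 3, `COc1ccccc1-c1cc(=O)c2cc(N)ccc2o1`, carries hydrogen in place of acetyl on a nitrogen on an aromatic ring, and in this assay compound 3 gives 74000 nM; the step of a 1.5-fold higher number from compound 1 to compound 3 (0.17 log units; within the scatter) stays within the scatter, so these two compounds are not told apart here. Compound 2, `CC(=O)Nc1ccc2oc(-c3ccccc3F)cc(=O)c2c1`, has fluoro in place of methoxy on an aromatic carbon. In this assay compound 2 reaches only a limit of the assay, > 125000 nM. The step of an at least 2.5-fold higher number from compound 1 to compound 2 (0.39 log units; beyond the scatter) is thus at least modest, resting on (the limit of > 125000 nM in this assay, at which 1 of the 3 values shown sits).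

Compound 4, `COc1ccccc1-c1oc2ccc(NC(C)=O)cc2c(=O)c1O`, differs from compound 1 in a single place: hydroxy in place of hydrogen on an aromatic carbon. Neither measured step touches a hydroxy group: one exchanges methoxy for fluoro, the other strips acetyl from a nitrogen. For the measured compounds named here, no measured step therefore bears directly on this change, and the expectation is a step of no change at the digits printed from compound 1 to compound 4 (within the scatter), nothing beyond the scatter in either direction. Compound 4 is accordingly expected to give about 50000 nM in this assay, with a range from 25000 nM to 110000 nM.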

Compound 4, half-maximal inhibitory concentration: > 125000 nM
Compound 4: a limit, no number (the forecaster's own chance of this, stated with the estimate: 25%); middle value at least 2.5-fold (0.39 log units) away from the limit.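

Hydroxy in place of hydrogen on an aromatic carbon of the core, ortho to a 2-methoxyphenyl group, is the first change shown at this position, and in this assay it gives an at least 2.5-fold higher number from compound 1 to compound 4 (0.39 log units; beyond the scatter). For the compounds shown here, the earlier steps touched only the methoxy on the 2-methoxyphenyl group and the acetyl on the nitrogen, so this result is the first to show that a change on the core of compound 1 itself can also move the number, here in the direction of weaker inhibition. For compound 4 the value > 125000 nM is a limit of the assay and not a number, so the step has only a lower bound and its full size stays unknown: the limit of > 125000 nM in this assay, at which 2 of the 4 values shown sit.

Only hydrogen and hydroxy appear at this position, which leaves open how an amine, a methoxy group or a carboxylic acid on the same carbon would read in this assay. Also open, from the compounds shown here alone, is whether the hydroxy step would look the same with the free amine of compound 3 or with the fluoro of compound 2 in the molecule.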